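The source may hold more compounds than are shown below. What is called first, only, known or untested is meant among the compounds shown, and "the series" means these compounds.

Measured compounds:
compound 1 `CCC(Sc1nc2c(cnn2C)c(=O)n1-c1ccccc1)c1ccccc1`: 150 nM
compound 2 `CC(Sc1nc2c(cnn2C)c(=O)n1-c1ccccc1)c1ccncc1`: 451 nM

In an assay on isolated protein for inhibition of aldehyde dehydrogenase 1A1 (Homo sapiens) (a lower number here means a stronger inhibitor, a higher number a weaker inhibitor), compound 1 gives 150 nM, and compound 2 gives 451 nM. Going by the values given here, compound 2 therefore holds the higher of the two numbers, the weaker inhibition, and the single step between them is a 3.0-fold higher number from compound 1 to compound 2 (0.48 log units; beyond the scatter), a change that touched both the chain on the sulfur and the ring carried by it.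

Compound 3 `COc1ccccc1C(C)Sc1nc2c(cnn2C)c(=O)n1-c1ccccc1` is the next member. It differs from compound 2 in one place: 2-methoxyphenyl in place of pyridin-4-yl on a saturated chain carbon bound to a saturated chain carbon and a sulfur. Among the compounds with values here, the only measured step that bears on this change is the one from compound 1 to compound 2, in which a carbon-only ring gave way to a nitrogen-containing ring and the number rose. Compound 3 brings back a carbon-only ring, now carrying a methoxy, while the chain stays as in compound 2. The two measured compounds show a modest gap, and the ring swap in compound 3 is expected to move the number back down by a comparable or smaller amount, a 2.1-fold lower number from compound 2 to compound 3 (0.31 log units; beyond the scatter). Compound 3 is thus estimated at 220 nM, with a likely range of 80 nM to 600 nM.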

Compound 3, half-maximal inhibitory concentration: 445 nM
For compound 3 the middle estimate is 2.0-fold (0.31 log units) below the measured one; the measured number falls inside the stated range.
By their numbers in this assay, from the lowest: compound 1; then compounds 3 and 2 (each within the scatter of the next).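

In this assay, the swap at this position, on a saturated chain carbon bound to a saturated chain carbon and a sulfur, gives a 1.0-fold lower number from compound 2 to compound 3 (0.01 log units; within the scatter); with the chain held fixed, pyridin-4-yl and 2-methoxyphenyl cannot be told apart in this assay. The earlier step, a 3.0-fold higher number from compound 1 to compound 2 (0.48 log units; beyond the scatter), changed the chain and the ring together, whereas this pair shows that a carbon-only ring does not by itself bring the number back down, at least when that ring carries a methoxy. No evidence is available to explain why these two rings give values within the scatter of each other.

The compounds shown leave open whether the gap between compound 1 and compound 2 belongs to the chain, to the ring or to both, a question that a plain phenyl on the chain of compound 2 could help to settle. They also leave open how this position would respond to a ring bearing a chlorine atom, an amine or a carboxylic acid in place of the methoxy.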